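Moving a methyl group on the amide aryl ring

This account rests on a few compounds, and the source may have more. Where it says the series, first, only, none or still open, it means among the compounds named here.

Measured compounds:
- compound 1, `O=C(Nc1cccc(-c2oc3cc(-c4ccc(F)cc4)ccc3c(=O)c2O)c1)c1ccc(F)cc1`: 6930 nM
- compound 2, `Cc1ccc(C(=O)Nc2cccc(-c3oc4cc(-c5ccc(F)cc5)ccc4c(=O)c3O)c2)cc1`: 6910 nM
- compound 3, `COc1ccccc1C(=O)Nc1cccc(-c2oc3cc(-c4ccc(F)cc4)ccc3c(=O)c2O)c1`: 11700 nM

All three were tested in a functional assay on A549 cells (Homo sapiens) for antiproliferative activity, read by CCK-8 assay, with a stated time of 72 h; on this read-out lower numbers stand for stronger inhibition and higher numbers for weaker inhibition. Compound 2 returns the smallest number of the three, but this says little: the step of a 1.0-fold lower number from compound 1 to compound 2 (0.00 log units; within the scatter) and the step of a 1.7-fold higher number from compound 2 to compound 3 (0.23 log units; within the scatter) both lie within the scatter, and so does the step of a 1.7-fold higher number from compound 1 to compound 3 (0.23 log units; within the scatter). On these numbers the three compounds cannot be told apart.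

Compound 4, `Cc1cccc(C(=O)Nc2cccc(-c3oc4cc(-c5ccc(F)cc5)ccc4c(=O)c3O)c2)c1`, has not yet been measured. It differs from compound 2 by one change: 3-methylphenyl in place of 4-methylphenyl on a carbonyl carbon. Within the data shown here, none of the measured steps involves this exact change, so the guidance is indirect. Changing the substituent on that ring, as in the step from compound 1 to compound 2, or swapping the whole aryl group, as in the steps to compound 3, left the read-out in this assay within the scatter each time. A change as small as moving a methyl group within the same ring is therefore expected to give a step of a 1.1-fold higher number from compound 2 to compound 4 (0.04 log units; within the scatter), that is, nothing beyond the scatter in either direction. Compound 4 is accordingly expected to give about 7500 nM in this assay, with a range from 3500 nM to 16000 nM.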

Compound 4, half-maximal inhibitory concentration: 16500 nM
The estimate for compound 4 lay 2.2-fold (0.34 log units) below the measured number; measured number above the stated range.
By their numbers in this assay, from the lowest: compounds 2, 1, 3 and 4 (each within the scatter of the next, the first and the last beyond it).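

Until now, every change to the aryl group on the carbonyl carbon stayed within the scatter, so this position looked tolerant of whatever was placed there. Going from 4-methylphenyl to 3-methylphenyl changes no atoms, only how they are joined, yet this assay records a 2.4-fold higher number from compound 2 to compound 4 (0.38 log units; beyond the scatter), the first step in this set to pass beyond the scatter, so the place of the methyl on the ring can matter even where swapping the group did not. The comparison with the fluorinated analogue gives the same size of step, a 2.4-fold higher number from compound 1 to compound 4 (0.38 log units; beyond the scatter), whereas a 1.4-fold higher number from compound 3 to compound 4 (0.15 log units; within the scatter) remains within the scatter, so compound 3 and compound 4 cannot be told apart.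

No measurement offered here accounts for the effect of moving the methyl. As far as these compounds go, the step is modest and rests on a single pair of isomers, so it remains open whether the same move would matter for other groups, such as an amine or a carboxylic acid in place of the methyl, and whether it would hold for the 3-methylphenyl arrangement on a different core.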